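Phenyl to methyl on compound 2

The source may hold more compounds than are shown below. What is called first, only, known or untested is meant among the compounds shown, and "the series" means these compounds.

In a functional assay on MDCK cells (Canis lupus familiaris) for inhibition (on this read-out higher numbers stand for lower toxicity in this test and lower numbers for higher toxicity in this test), compound 2 (`CCCOc1nc(CC2(c3ccccc3)CCCO2)cc(=O)n1C`) gives 170000 nM and compound 3 (`CCCCOc1nc(CC2(c3ccccc3)CCCO2)cc(=O)n1C`) gives 90000 nM. These two are not separated. Compound 1 (`Cn1c(CC2(C)CO2)cc(=O)n(C)c1=O`) gives 4000 nM, a much lower number than compound 2 and beyond the scatter. Compound 1 also carries methyl and no phenyl, but its core differs, so it offers only weak guidance.

Compound 4 (`CCCOc1nc(CC2(C)CCCO2)cc(=O)n1C`) differs from compound 2 by methyl in place of phenyl on a saturated ring carbon, next to the ring oxygen. For the measured compounds named here, the only measured step is a 1.9-fold lower number from compound 2 to compound 3 (0.28 log units; within the scatter). Going by the values given here, it lies on the chain, and no measured pair tests the loss of phenyl. On that thin evidence, no step beyond the scatter is expected in this assay, though the uncertainty is wide and leans towards lower numbers. The estimated step is a 1.4-fold lower number from compound 2 to compound 4 (0.15 log units; within the scatter). Compound 4 is estimated at 120000 nM, with an expected range of 40000 nM to 300000 nM.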

Compound 4, half-maximal cytotoxic concentration: 860000 nM
Beside the measured number, compound 4's estimate is 7.2-fold (0.86 log units) below it; the whole stated range lies below it.
By their numbers in this assay, from the lowest: compound 1; then compounds 3 and 2 (each within the scatter of the next); then compound 4.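

In this assay, for the compounds shown here, the change of phenyl to methyl on a saturated ring carbon, next to the ring oxygen, gives a 5.1-fold higher number from compound 2 to compound 4 (0.70 log units; beyond the scatter) and is the first step between closely matched compounds to lie beyond the scatter. The chain step of a 1.9-fold lower number from compound 2 to compound 3 (0.28 log units; within the scatter) stays within the scatter, so among the two single-place changes shown, only the one at the ring carbon separates compounds, here towards lower toxicity in this test. Nothing available explains this step.

Going by these compounds, only phenyl and methyl appear at this ring carbon, so it remains open whether ethyl, cyclohexyl or hydroxymethyl there would give numbers closer to compound 2 or to compound 4. On these data alone, it is also open whether the same change carries over to the longer chain of compound 3.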